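The compounds below may be only part of what the source reports. "The series", "measured", "known", "first", "only" and "open" are said of these compounds alone.

For the measured compounds named here, compound 2 `COc1ccc(Cn2c(-c3ccc(C)cc3)c(Br)c(=O)c3cc([N+](=O)[O-])ccc32)cc1` stands at one end of the two numbers so far obtained in an assay on isolated protein for inhibition of Intestinal-type alkaline phosphatase (Bos taurus), read by spectrophotometry, with stated times of 7 min and 15 min (a lower number here means a stronger inhibitor, a higher number a weaker inhibitor), where compound 2 gives 2430 nM; compound 1 `CCCCCc1cc(=O)c2cc([N+](=O)[O-])ccc2n1Cc1ccc(OC)cc1` gives 1380 nM in this assay, and the gap between the two lies within the usual scatter of such measurements. Compound 3 `CCCCCc1c(Br)c(=O)c2cc([N+](=O)[O-])ccc2n1Cc1ccc(OC)cc1` differs from compound 2 by pentyl in place of 4-methylphenyl on an aromatic carbon. Going by the values given here, no step between measured compounds is available to gauge this change, so the expected step is a 1.4-fold lower number from compound 2 to compound 3 (0.13 log units; within the scatter), no larger than the scatter. Compound 3 is therefore estimated to give 1800 nM in this assay, with a likely range from 700 nM to 4500 nM.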

Compound 3, half-maximal inhibitory concentration: 122000 nM
Estimate against measurement, compound 3: 68-fold (1.83 log units) below; the whole stated range lies below it.
By their numbers in this assay, from the lowest: compounds 1 and 2 (each within the scatter of the next); then compound 3.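

In this assay, replacing 4-methylphenyl with pentyl next to the ring nitrogen, with bromo kept, gives a 50-fold higher number from compound 2 to compound 3 (1.70 log units; beyond the scatter) and shows that this position is far from indifferent to the group it carries. With pentyl kept, bromo in place of hydrogen gives an 88-fold higher number from compound 1 to compound 3 (1.95 log units; beyond the scatter) and shows that the two groups together are poorly accepted. Nothing measured here explains either step.

Going by these compounds, whether bromo is harmful alongside 4-methylphenyl remains open. So does how a shorter chain such as ethyl, or an unsubstituted phenyl ring, would fare at this position.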